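Swapping a Trifluoromethylphenyl for Pyridinyl: An Expected Recovery

This account rests on a few compounds, and the source may have more. Where it says the series, first, only, none or still open, it means among the compounds named here.

Compound 1, `COc1cccc(-c2nc(C(F)(F)F)n(CC[C@@H](O)C[C@@H](O)CC(=O)O)c2-c2ccc(F)cc2)c1`, gives 20 nM in an assay on microsomes from liver for inhibition of 3-hydroxy-3-methylglutaryl-coenzyme A reductase (Rattus norvegicus); on this read-out lower numbers stand for stronger inhibition and higher numbers for weaker inhibition.
Compound 2, `O=C(O)C[C@H](O)C[C@H](O)CCn1c(C(F)(F)F)nc(-c2ccc(F)cc2)c1-c1ccc(F)cc1`, gives 38 nM in this assay.
Compound 3, `O=C(O)C[C@H](O)C[C@H](O)CCn1c(C(F)(F)F)nc(-c2ccc(C(F)(F)F)cc2)c1-c1ccc(F)cc1`, gives 200 nM in this assay.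

Compound 3 stands highest of the three numbers in this assay; compound 2 is nearest and compound 1 furthest, both differences beyond the scatter. The steps into compound 3 were a 5.3-fold higher number from compound 2 to compound 3 (0.72 log units; beyond the scatter) and a 10-fold higher number from compound 1 to compound 3 (1.00 log units; beyond the scatter), so the group on this aromatic carbon clearly matters. Compound 4, `O=C(O)C[C@H](O)C[C@H](O)CCn1c(C(F)(F)F)nc(-c2cccnc2)c1-c1ccc(F)cc1`, differs from compound 3 in one place: pyridin-3-yl in place of 4-(trifluoromethyl)phenyl on an aromatic carbon. Within the data shown here, no measured step involves pyridin-3-yl, so the bearing steps are only those in which 4-(trifluoromethyl)phenyl entered, both worsening. Because a 5.3-fold higher number from compound 2 to compound 3 (0.72 log units; beyond the scatter) followed the move from fluoro to trifluoromethyl, taking the trifluoromethyl group away again is expected to undo part of that loss. Compound 4 is therefore expected to show a step of a 4.0-fold lower number from compound 3 to compound 4 (0.60 log units; beyond the scatter). Compound 4 is estimated to give 50 nM in this assay, within a range from 15 nM to 160 nM.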

Compound 4, half-maximal inhibitory concentration: 66 nM
For compound 4 the middle estimate is 1.3-fold (0.12 log units) below the measured one; measured number inside the range.
By their numbers in this assay, from the lowest: compounds 1, 2 and 4 (each within the scatter of the next, the first and the last beyond it); then compound 3.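

Pyridin-3-yl in place of 4-(trifluoromethyl)phenyl gives a 3.0-fold lower number from compound 3 to compound 4 (0.48 log units; beyond the scatter) in this assay, which shows that this aromatic carbon also accepts a ring with a hetero atom and that much of the loss seen with 4-(trifluoromethyl)phenyl does not carry over to it. Pyridin-3-yl cannot be told apart from 4-fluorophenyl, with a 1.7-fold higher number from compound 2 to compound 4 (0.24 log units; within the scatter) in this comparison, yet it does not match 3-methoxyphenyl, as a 3.3-fold higher number from compound 1 to compound 4 (0.52 log units; beyond the scatter) shows. The data offer no explanation for these differences.

A plain phenyl group, a pyridin-4-yl group or a phenyl ring carrying an amine on this carbon would help separate the effect of the ring nitrogen from that of losing the trifluoromethyl group. As far as these compounds go, in compound 4 the two changes come together, so their separate contributions remain open.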